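Working notes: compound 3 to compound 4 in the agonist series

A few compounds are considered here, and "the series" means these few. Any claim that something is new, unique, unknown or untested is made for them only; others in the source may bear on it.

Compound 3 `COc1cccc(C(=O)N(C)c2cccc3ccc(NS(=O)(=O)c4cc(-c5cccc(C(=O)N(C)C)c5)ccc4OC)cc23)c1` gives 101% in a functional assay on CHO cells for agonist activity at Orexin/Hypocretin receptor type 1 (Homo sapiens) (a lower number here means a smaller maximal response, a higher number a larger maximal response), the lowest of the two numbers at hand. Compound 1 `COc1cccc(C(=O)Nc2cccc3ccc(NS(=O)(=O)c4cc(-c5cccc(C(=O)N(C)C)c5)ccc4OC)cc23)c1` gives 107% in this assay, and the step of a number 6 percentage points lower from compound 1 to compound 3 (within the scatter) lies within the scatter. Compound 2 `COc1ccccc1C(=O)N(C)c1cccc2ccc(NS(=O)(=O)c3cc(-c4cccc(C(=O)N(C)C)c4)ccc3OC)cc12` gives "nd" (no result reported) in this assay, that is, no result was reported for it. Compound 4 `COc1ccc(C(=O)N(C)c2cccc3ccc(NS(=O)(=O)c4cc(-c5cccc(C(=O)N(C)C)c5)ccc4OC)cc23)cc1` differs from compound 3 by 4-methoxyphenyl in place of 3-methoxyphenyl on a carbonyl carbon. Among the compounds with values here, no measured step exchanges 3-methoxyphenyl for 4-methoxyphenyl on the carbonyl carbon; the only step known, a number 6 percentage points lower from compound 1 to compound 3 (within the scatter), concerns the amide-type nitrogen and stayed within the scatter, so no shift beyond the scatter is expected here either. Compound 4 is estimated at 100% in this assay, with a range from 85% to 115%. The expected step is a number 1 percentage points lower from compound 3 to compound 4 (within the scatter).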

Compound 4, largest response reached (Emax), in percent of the reference or control that the assay uses: 87.8%
Beside the measured number, compound 4's estimate is 12.2 percentage points above it, and the stated range covers the measured number.
By their numbers in this assay, from the lowest: compound 4; then compounds 3 and 1 (each within the scatter of the next).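

In this assay, within the data shown here, the exchange of 3-methoxyphenyl for 4-methoxyphenyl on the carbonyl carbon gives a number 13.2 percentage points lower from compound 3 to compound 4 (beyond the scatter) and is the first single change to pass the scatter, so the maximal response depends on this position. Together with the methyl on the amide-type nitrogen, the change amounts to a number 19.2 percentage points lower from compound 1 to compound 4 (beyond the scatter) and remains modest. Nothing at hand accounts for this drop.

Still open, as far as these compounds go, is whether the drop is specific to methoxy or also appears with 4-hydroxyphenyl or 4-fluorophenyl on the same carbonyl carbon. From the compounds shown here alone, it is also open whether 4-methoxyphenyl gives the same step when the amide-type nitrogen carries hydrogen instead of methyl.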